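Two cyclobutyloxy groups on a tetradecyl pyrimidinediol

A few compounds are considered here, and "the series" means these few. Any claim that something is new, unique, unknown or untested is made for them only; others in the source may bear on it.

Measured so far:
compound 1, `CCCCCCCCCCCCCCc1nc(N2CCC2)nc(OC2CCC2)c1O`, 102%
compound 2, `CCCCCCCCCCCCCCc1nc(OC2CCC2)nc(N2CCC2)c1O`, 105%

Both compounds were tested in a functional assay on cells (Lymphocyte, Homo sapiens), read by a luciferase reporter and ATP content, with a stated time of 48 h, tested at 5 uM; a lower number here means a stronger effect, a higher number a weaker effect of the compound at the concentration tested. Compound 1 gives 102%, and compound 2 gives 105%. The two numbers lie within the usual scatter of each other, so neither can be told apart from the other, and both sit at the level of an untreated control: at the concentration tested, neither compound shows a measurable effect.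

Compound 3, `CCCCCCCCCCCCCCc1nc(OC2CCC2)nc(OC2CCC2)c1O`, has not yet been measured. It is made from compound 2 by one change: cyclobutyloxy in place of azetidin-1-yl on an aromatic carbon. After this change compound 3 carries a cyclobutyloxy group on each of the two positions that flank the hydroxy group, with the tetradecyl chain unchanged.

For the measured compounds named here, no step between measured compounds is known, so there is nothing to scale from. Since compound 1 and compound 2 both read as inactive, compound 3 is expected to read the same, with the step of a number 5 percentage points lower from compound 2 to compound 3 (within the scatter) expected to stay within the scatter. Compound 3 is therefore estimated at 100%, in the range 85% to 115%.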

Compound 3, a percentage reported as activity, at one concentration (the size of the read-out at that concentration, not a potency): 98%
Estimate against measurement, compound 3: 2 percentage points above; the range from low to high includes it.
By their numbers in this assay, from the lowest: compounds 3, 1 and 2 (each within the scatter of the next).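

In this assay, placing cyclobutyloxy in place of azetidin-1-yl ortho to a hydroxy group gives a number 7 percentage points lower from compound 2 to compound 3 (within the scatter) and the same exchange at the other azetidin-1-yl place on the core gives a number 4 percentage points lower from compound 1 to compound 3 (within the scatter) as its result. Compounds 1 and 2 only showed the two groups trading places, whereas these steps exchange one group for the other at a single place while all else stays the same, and at neither place can the reading be told apart from that of the parent compound. At the concentration tested, then, azetidin-1-yl and cyclobutyloxy cannot be distinguished at either place, and no information on why this is so is available.

On these data alone, all three compounds share the tetradecyl chain and carry only these two four-membered ring groups, so it remains open whether a dimethylamino group or a carboxylic acid at either place would move the reading. As far as these compounds go, it is equally open whether a shorter octyl chain would do so, and a reading at one concentration cannot show what happens at higher concentrations.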